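The source may hold more compounds than are shown below. What is called first, only, known or untested is meant among the compounds shown, and "the series" means these compounds.

Measured so far in an ADME assay on HUVEC cells (Homo sapiens) for cytotoxicity, read by MTT assay, with a stated time of 2 days; a higher number here means a weaker inhibitor, a lower number a stronger inhibitor:
compound 1, `c1ccc(CO/N=C2/C(c3c[nH]c4ccccc34)=Nc3ccccc32)cc1`, gives > 100000 nM, which is a limit of the measurement and not a number.
compound 2, `Cc1ccc(CO/N=C2/C(c3c[nH]c4ccc(Br)cc34)=Nc3ccc(Br)cc32)cc1`, gives > 100000 nM, likewise a limit.

Among the measured compounds shown here, compound 1 therefore has no position on a scale of numbers: its own value is a limit, and the one further value shown, that of compound 2, is a limit as well. The whole of the evidence is the limit of > 100000 nM in this assay, at which 2 of the 2 values shown sit. For the measured compounds named here, no step between measured compounds exists, so no measured size of change can be leaned on.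

Compound 3, `FC(F)(F)c1ccc(CO/N=C2/C(c3c[nH]c4ccccc34)=Nc3ccccc32)cc1`, differs from compound 1 by trifluoromethyl in place of hydrogen on an aromatic carbon. Of this step only the structural change is known. Given (the limit of > 100000 nM in this assay, at which 2 of the 2 values shown sit), the expected step is none beyond the scatter, and compound 3 is expected to stay at the limit, so the figure set down is nominal. The step expected is a step that the limit leaves unreadable from compound 1 to compound 3. Compound 3 is estimated at 150000 nM, with a range from 50000 nM to 500000 nM.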

Compound 3, half-maximal inhibitory concentration: > 100000 nM
Compound 3 was reported as a limit; the forecaster's own chance of this, stated with the estimate: 85%; the middle value is on the limit's open side.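

In this assay, among the compounds shown here, compound 3 gives > 100000 nM, which is a limit and not a number, and no step from compound 1 to compound 3 can be read: the limit of > 100000 nM in this assay, at which 3 of the 3 values shown sit.

The compounds shown leave open how far each lies past that limit, and whether trifluoromethyl in place of hydrogen changes anything in this assay.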